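Replacing 3-amino-5-fluorophenyl with 4-cyanophenyl under a cytotoxicity limit

This account rests on a few compounds, and the source may have more. Where it says the series, first, only, none or still open, it means among the compounds named here.

Of the compounds shown here, two on one shared core have been read so far. In a functional assay on HEK293 cells (Homo sapiens) for cytotoxicity (a higher number here means that more compound is tolerated, a lower number that less compound is tolerated), compound 1 `COc1ccc([C@H]2CC(=O)N(c3ccc(C)c(N)c3)C2)cc1OC1CCCC1` gives > 10000 nM which is a limit and not a number. Compound 2 `COc1ccc([C@H]2CC(=O)N(c3cc(N)cc(F)c3)C2)cc1OC1CCCC1` stands at > 10000 nM which is again a limit, so its place is known only from one side. The record to date is the limit of > 10000 nM in this assay, at which 2 of the 2 values shown sit, and it holds nothing more. Among the measured compounds shown here, the single measured change is a step that the two limits leave unreadable from compound 1 to compound 2 and it offers no size to carry forward.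

Compound 3 `COc1ccc([C@H]2CC(=O)N(c3ccc(C#N)cc3)C2)cc1OC1CCCC1` keeps the core and carries 4-cyanophenyl in place of 3-amino-5-fluorophenyl on an amide-type nitrogen in a ring as its only difference. For the measured compounds named here, since compound 2 reads > 10000 nM as a limit, no step of readable size is expected in this assay and no direction can be named. The expected change is an estimated step that the limit leaves unreadable from compound 2 to compound 3 and it should not go beyond the scatter. For compound 3 the estimated value is 15000 nM with an expected range from 6000 nM to 40000 nM and a report as a limit is the likeliest outcome.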

Compound 3, half-maximal cytotoxic concentration: > 10000 nM
Compound 3: no number, only a limit; the forecaster's own chance of this, stated with the estimate: 85%; the middle value is on the limit's open side.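

Compound 3 also gives only a limit in this assay, so its steps from compound 1 and compound 2 cannot be read. All three compounds share the same limit: the limit of > 10000 nM in this assay, at which 3 of the 3 values shown sit.

The compounds shown leave open at what concentration any of them becomes cytotoxic, and whether the three groups on the amide-type nitrogen differ at all.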